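Series notes: phenyl to 4-methoxyphenyl

The source may hold more compounds than are shown below. What is called first, only, known or untested is meant among the compounds shown, and "the series" means these compounds.

In a functional assay on DU-145 cells (Homo sapiens) for cytotoxicity, read by trypan blue exclusion, with a stated time of 96 h (a higher number here means a weaker inhibitor, a lower number a stronger inhibitor), compound 1 `COC(=O)[C@H](C)Nc1cc(CS(=O)(=O)/C=C/c2c(OC)cc(OC)cc2OC)ccc1OC` gives 750 nM, compound 2 `COC(=O)C(C)(C)Nc1cc(CS(=O)(=O)/C=C/c2c(OC)cc(OC)cc2OC)ccc1OC` gives 2500 nM, and compound 3 `COC(=O)C(Nc1cc(CS(=O)(=O)/C=C/c2c(OC)cc(OC)cc2OC)ccc1OC)c1ccccc1` gives 75 nM, the lowest of the three numbers. Compound 4 `COC(=O)C(Nc1cc(CS(=O)(=O)/C=C/c2c(OC)cc(OC)cc2OC)ccc1OC)c1ccc(OC)cc1` differs from compound 3 by methoxy in place of hydrogen on an aromatic carbon, para to a large group: methoxy in place of hydrogen on an aromatic carbon. The closest evidence is the modest step of a 10-fold lower number from compound 1 to compound 3 (1.00 log units; beyond the scatter) and the large step of a 33-fold lower number from compound 2 to compound 3 (1.52 log units; beyond the scatter). Both show sensitivity to the group on the nitrogen, yet neither tests a substituent on the phenyl ring, so no firm direction follows. The estimated step of a 1.2-fold higher number from compound 3 to compound 4 (0.08 log units; within the scatter) is therefore expected to be small. For compound 4 the expected value is 90 nM, with an estimated range of 30 nM to 270 nM.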

Compound 4, half-maximal inhibitory concentration: 250 nM
Beside the measured number, compound 4's estimate is 2.8-fold (0.44 log units) below it; the range from low to high includes it.
By their numbers in this assay, from the lowest: compound 3; then compound 4; then compound 1; then compound 2.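

Methoxy in place of hydrogen on an aromatic carbon, para to a large group, is the only change shown on the phenyl ring itself, and in this assay it gives a 3.3-fold higher number from compound 3 to compound 4 (0.52 log units; beyond the scatter). Among the compounds shown here, this ring position therefore responds to substitution, whereas the earlier steps showed sensitivity only to the group on the nitrogen. No measurement bearing on the reason for this step is available. From the compounds shown here alone, whether the rise belongs to methoxy specifically or to any substituent at this carbon stays open; fluorine, hydroxyl or a carboxylic acid there would help separate the two.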